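The compounds below may be only part of what the source reports. "The series", "measured", "known", "first", "only" and "open" are said of these compounds alone.

Compound 1 `O=[N+]([O-])c1ccccc1CSc1nnc(-c2ccc3c(c2)OCCO3)n1-c1ccccc1`: 8300 nM
Compound 2 `Clc1cccc(CSc2nnc(-c3ccc4c(c3)OCCO4)n2-c2ccccc2)c1`: 10600 nM
Compound 3 `COc1cccc(CSc2nnc(-c3ccc4c(c3)OCCO4)n2-c2ccccc2)c1`: 10100 nM

These numbers come from a functional assay on SW 1116 cells (Homo sapiens) for antiproliferative activity, read by MTT assay, with a stated time of 24 h; a lower number here means a stronger inhibitor, a higher number a weaker inhibitor. Compound 3 stands second highest of the three; the steps of a 1.0-fold lower number from compound 2 to compound 3 (0.02 log units; within the scatter) and a 1.2-fold higher number from compound 1 to compound 3 (0.09 log units; within the scatter) show how close the other two lie to it. Compound 4 `Fc1ccccc1CSc1nnc(-c2ccc3c(c2)OCCO3)n1-c1ccccc1` differs from compound 3 by 2-fluorophenyl in place of 3-methoxyphenyl on a saturated chain carbon bound to a sulfur. The measured steps that bear on this change are a 1.3-fold higher number from compound 1 to compound 2 (0.11 log units; within the scatter) and a 1.2-fold higher number from compound 1 to compound 3 (0.09 log units; within the scatter), each an exchange of the group on the same saturated chain carbon bound to a sulfur, and each within the scatter. The three measured compounds therefore give no sign that this group shifts the number, so for compound 4 no step beyond the scatter is expected, a 1.1-fold lower number from compound 3 to compound 4 (0.03 log units; within the scatter). Compound 4 is estimated at 9500 nM, with a range from 5000 nM to 19000 nM.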

Compound 4, half-maximal inhibitory concentration: 13600 nM
The estimate for compound 4 lay 1.4-fold (0.16 log units) below the measured number; the measured number falls inside the stated range.
By their numbers in this assay, from the lowest: compounds 1, 3, 2 and 4 (each within the scatter of the next).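

With compound 4, a fluoro group joins the nitro, chloro and methoxy groups on the benzyl ring, and in this assay every new step stays within the scatter (a 1.3-fold higher number from compound 3 to compound 4 (0.13 log units; within the scatter) and a 1.3-fold higher number from compound 2 to compound 4 (0.11 log units; within the scatter) and a 1.6-fold higher number from compound 1 to compound 4 (0.21 log units; within the scatter)). Across these four compounds, then, no exchange at this position moves the number beyond the scatter, even the direct swap of nitro for fluoro. No measurement shown offers an explanation for this. Still open, on these data alone, is whether an amine or a carboxylic acid on the ring, or a longer chain on the sulfur, would give a step beyond the scatter.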